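The source may report more compounds than this note shows. Statements on the series, on what has been measured and on what is new or still open speak of the compounds shown alone.

Among the measured compounds shown here, compound 3 `O=C1NC(=O)/C(=C/c2ccc(OCCSc3nnc(-c4ccccc4[N+](=O)[O-])[nH]3)cc2)S1` stands highest of the three numbers so far in a functional assay on the whole organism (strain Wistar) with Rattus norvegicus as the target, with a stated time of 15 days, at a dose of 10 mg/kg by the oral route (on this read-out lower numbers stand for a weaker effect and higher numbers for a stronger effect at the one dose given), where compound 3 gives 20.9%. Its nearest neighbour is compound 1 `O=C1NC(=O)/C(=C/c2ccc(OCCSc3nnc(-c4ccccc4)[nH]3)cc2)S1`, for which compound 1 gives 19.2%, and the furthest is compound 2 `O=C1NC(=O)/C(=C/c2ccc(OCCSc3nnc(-c4ccc([N+](=O)[O-])cc4)[nH]3)cc2)S1`, for which compound 2 gives 15.3%; both gaps lie within the scatter, so none of the three can be called stronger or weaker than another.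

The step to compound 4 `O=C1NC(=O)/C(=C/c2ccc(OCCSc3nnc(-c4ccc(Cl)cc4)[nH]3)cc2)S1` is 4-chlorophenyl in place of 2-nitrophenyl on an aromatic carbon. For the measured compounds named here, no measured step introduces a chlorine, so only the three steps among the aryl groups bear on it indirectly: a number 3.9 percentage points lower from compound 1 to compound 2 (within the scatter), a number 1.7 percentage points higher from compound 1 to compound 3 (within the scatter) and a number 5.6 percentage points higher from compound 2 to compound 3 (within the scatter). All three stayed within the scatter, which shows that changing the substituent on this phenyl ring, or moving it, left this assay essentially unmoved across compounds 1, 2 and 3.

On that basis the author expects no step beyond the scatter in this assay from compound 3 to compound 4, namely a number 1.9 percentage points lower from compound 3 to compound 4 (within the scatter). Compound 4 is therefore estimated at 19%, with a range from 10% to 28%, and the measurement will tell whether the chlorine behaves like the groups seen so far.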

Compound 4, a percentage reported as activity, at one dose (the size of the read-out at that dose, not a potency): 24.6%
Compound 4: the middle estimate sits 5.6 percentage points below what was measured; the range from low to high includes it.
By their numbers in this assay, from the lowest: compounds 2, 1, 3 and 4 (each within the scatter of the next).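

Chloro is a new kind of substituent on this phenyl ring, yet in this assay it still does not separate compound 4 from the other three: the result is a number 5.4 percentage points higher from compound 1 to compound 4 (within the scatter), a number 3.7 percentage points higher from compound 3 to compound 4 (within the scatter) and a number 9.3 percentage points higher from compound 2 to compound 4 (within the scatter). That last step, chloro in place of nitro with the group on the ring otherwise unchanged, is the largest seen so far at this position on the five-membered aromatic ring, but it too remains inside the scatter, so the four aryl groups now tested cannot be ranked. The compounds offer no measurement that could explain why these groups read alike.

From the compounds shown here alone, it remains open whether any group at this place can move the read-out beyond the scatter, for example an amine or a carboxylic acid on the phenyl ring, or a longer alkyl chain in place of the phenyl ring itself. All four compounds also share the same core and were read at a single dose, so how far this flat picture holds at other doses or with a changed core is equally unsettled.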